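The source may report more compounds than this note shows. Statements on the series, on what has been measured and on what is new or still open speak of the compounds shown alone.

In a functional assay on HL-60 cells (Homo sapiens), read by calcium flux (on this read-out lower numbers stand for an effect already at smaller amounts and higher numbers for an effect only at larger amounts of compound), compound 1 `Cc1cc(Cc2ccccc2)c(=O)n(CC(=O)Nc2ccc(Br)cc2)n1` gives a value that is a limit of the assay, > 50000 nM.
In this assay compound 2 `Cc1cc(Cc2ccoc2)c(=O)n(CC(=O)Nc2ccc(Br)cc2)n1` likewise gives only a limit, > 50000 nM.
In this assay compound 3 `Cc1cc(Cc2cccs2)c(=O)n(CC(=O)Nc2ccc(Br)cc2)n1` also gives only a limit, > 50000 nM.

Compound 3 therefore stands where every measured compound in this series stands: at the limit of > 50000 nM in this assay, at which 3 of the 3 values shown sit. No measured value is a number. The three steps between the measured compounds, a step that the two limits leave unreadable from compound 1 to compound 2, a step that the two limits leave unreadable from compound 1 to compound 3 and a step that the two limits leave unreadable from compound 2 to compound 3, cannot be read in size or direction, since each connects two limits.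

Compound 4 `Cc1cc(Cc2ccc(C(N)=O)cc2)c(=O)n(CC(=O)Nc2ccc(Br)cc2)n1` differs from compound 3 in one place: 4-carbamoylphenyl in place of thiophen-2-yl on a saturated chain carbon bound to an aromatic carbon. For the measured compounds named here, the exchange of one aromatic group for another on the same chain carbon is the kind of change that the measured steps describe, yet none of them gives a readable size, so they offer no scale for the step. What they do show is that three different groups on that carbon all left the compound at the limit of this assay.

On that basis compound 4 is expected to sit at the limit again, with an estimate of 100000 nM in a range from 20000 nM to 500000 nM. The step this estimate means, a step that the limit leaves unreadable from compound 3 to compound 4, is expected to be unreadable, with the value most likely reported only as a limit.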

Compound 4, half-maximal effective concentration: > 50000 nM
Compound 4 ended at the assay's limit; the forecaster's own chance of this, stated with the estimate: 85%; the middle value does not contradict the limit.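

In this assay compound 4 gives > 50000 nM, which is a limit of the assay. Its steps from compound 1, compound 2 and compound 3 cannot be read, since each connects two limits: the limit of > 50000 nM in this assay, at which 4 of the 4 values shown sit. The compounds shown leave open which group on the saturated chain carbon, if any, would give a numerical value in this assay.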